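Moving a hydroxy-free ester between two sugar-like cores

A few compounds are considered here, and "the series" means these few. Any claim that something is new, unique, unknown or untested is made for them only; others in the source may bear on it.

Three esters of a hydroxylated cyclohexane core have been tested in a functional assay on BV-2 cells (Mus musculus) for inhibition, read by Griess assay, with a stated time of 10 min; a higher number here means a weaker inhibitor, a lower number a stronger inhibitor. Compound 1 `COC(=O)[C@]1(O)C[C@@H](O)[C@@H](OC(=O)/C=C/c2ccc(O)c(O)c2)[C@H](O)C1` carries a 3,4-dihydroxyphenyl group on its side chain and gives 16600 nM. Compound 2 `COC(=O)[C@]1(O)C[C@@H](O)[C@@H](O)[C@H](OC(=O)/C=C/c2ccc(O)c(O)c2)C1` is built from the same atoms as compound 1, joined differently; how the two cores differ is not broken down here. In this assay compound 2 gives 12100 nM, and the two values lie within the usual scatter of each other, so no order between them can be claimed. Compound 3 `COC(=O)[C@]1(O)C[C@@H](O)[C@@H](OC(=O)/C=C/c2ccc(O)cc2)[C@H](O)C1` is compound 1 with hydrogen in place of hydroxy on an aromatic carbon. In this assay compound 3 gives 45000 nM. Within the data shown here, this change made a step of a 2.7-fold higher number from compound 1 to compound 3 (0.43 log units; beyond the scatter), that is, the ester with only one hydroxy on the ring is the weaker inhibitor of the pair.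

Compound 4 `COC(=O)[C@]1(O)C[C@@H](O)[C@@H](O)[C@H](OC(=O)/C=C/c2ccc(O)cc2)C1` stands to compound 2 as compound 3 stands to compound 1: the difference is hydrogen in place of hydroxy on an aromatic carbon, and the place is described in the same words in both cases, so it is the same change. The expectation for compound 4 rests on a single earlier example, the step of a 2.7-fold higher number from compound 1 to compound 3 (0.43 log units; beyond the scatter) from compound 1 to compound 3, and carries that example's uncertainty. On that basis the step from compound 2 to compound 4 in this assay is expected to be a 2.7-fold higher number from compound 2 to compound 4 (0.44 log units; beyond the scatter). Compound 4 is therefore estimated at 33000 nM in this assay, most likely between 15000 nM and 75000 nM.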

Compound 4, half-maximal inhibitory concentration: 82000 nM
For compound 4 the middle estimate is 2.5-fold (0.40 log units) below the measured one; measured number above the stated range.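

In this assay, going from 3,4-dihydroxyphenyl to 4-hydroxyphenyl on the core of compound 2 gives a 6.8-fold higher number from compound 2 to compound 4 (0.83 log units; beyond the scatter), so the loss of this one hydroxy weakens inhibition on both cores shown, as it did on the core of compound 1. Set side by side, the two steps cannot be told apart in size: the same change on two cores in this assay, a 2.7-fold higher number (0.43 log units; beyond the scatter) from compound 1 to compound 3 and a 6.8-fold higher number (0.83 log units; beyond the scatter) from compound 2 to compound 4, 2.5-fold (0.40 log units) apart, within the scatter of two such steps. This supports carrying the direction of the change from one of these cores to the other, and the larger number on the second core should not be read as a real difference between the cores, but two pairs of compounds say nothing about other cores and do not explain why the hydroxy matters.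

On these data alone, all four compounds keep a hydroxy on the aromatic ring, so it remains open how a plain phenyl group would behave, or whether a methoxy group or a fluorine atom could stand in for the hydroxy that was removed. The methyl ester on the core is also the same throughout, which leaves open what a carboxylic acid or an amide in that place would do.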